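Compound 2 to compound 4: methoxy replaced by tert-butyl

A few compounds are considered here, and "the series" means these few. Any claim that something is new, unique, unknown or untested is made for them only; others in the source may bear on it.

Going by the values given here, in a functional assay on A549 cells (Homo sapiens) for inhibition, read by CCK-8 assay, with a stated time of 72 h, tested at 8 uM (a lower number here means less inhibition of growth, a higher number more inhibition of growth at the concentration tested), compound 2 (`COc1ccc(SCc2ccc(C(=O)Nc3ccccc3N)cc2)cc1`) gives 70.7%, the highest of the three numbers so far and beyond the scatter from both others. Compound 1 (`Nc1ccccc1NC(=O)/C=C/c1ccc(CSc2ccc(Cl)cc2)cc1`) gives 59.6%, and compound 3 (`Nc1ccccc1NC(=O)/C=C/c1ccc(CSc2ccc(C(F)(F)F)cn2)cc1`) gives 56.5%. Compound 4 (`CC(C)(C)c1ccc(SCc2ccc(C(=O)Nc3ccccc3N)cc2)cc1`) differs from compound 2 by tert-butyl in place of methoxy on an aromatic carbon, para to a large group. Among the compounds with values here, no measured step changes this group on the core of compound 2, so the evidence is indirect. Within the data shown here, the only measured step, a number 3.1 percentage points lower from compound 1 to compound 3 (within the scatter), exchanges the group on the sulfur and stays within the scatter. That single step suggests limited sensitivity to changes on that side, so no step beyond the scatter is expected, with a slight drop from the high value of compound 2 as the best guess. The expected step is a number 5.7 percentage points lower from compound 2 to compound 4 (within the scatter). For compound 4 the estimated value is 65%, with an expected range of 48% to 79%.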

Compound 4, percent growth inhibition at one concentration: 67%
The estimate for compound 4 lay 2 percentage points below the measured number; the range from low to high includes it.
By their numbers in this assay, from the lowest: compounds 3, 1, 4 and 2 (each within the scatter of the next, the first and the last beyond it).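

In this assay, going by these compounds alone, the first measured change at this position on the core of compound 2, tert-butyl in place of methoxy on an aromatic carbon para to a large group, gives a number 3.7 percentage points lower from compound 2 to compound 4 (within the scatter). At least for this pair, the position accepts tert-butyl, with 4 heavy atoms and 0 hydrogen-bond acceptors, in place of methoxy, with 2 heavy atoms and 1 hydrogen-bond acceptor, without a step beyond the scatter, so the oxygen of methoxy is not needed to stay within the scatter of compound 2 in this read-out. No available measurement bears on why the two compounds read alike.

From the compounds shown here alone, whether an amine or a carboxylic acid at this position would also stay within the scatter of compound 2 remains open. Also open, going by these compounds, is whether the exchange of methoxy for tert-butyl would give a similar step on the core of compound 1.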